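A few compounds are considered here, and "the series" means these few. Any claim that something is new, unique, unknown or untested is made for them only; others in the source may bear on it.

Measured so far:
compound 1 `Cc1cnc(C(=O)Nc2cccc3ccc(C)nc23)cn1`: > 10000 nM
compound 2 `Cc1cnc(C(=O)Nc2cc(F)cc3cccnc23)cn1`: > 10000 nM
compound 3 `Cc1ccc2cccc(NC(=O)c3cnccn3)c2n1`: > 10000 nM

In a functional assay on BXPC-3 cells (Homo sapiens) for inhibition, read by MTT assay, with a stated time of 72 h (on this read-out higher numbers stand for weaker inhibition and lower numbers for stronger inhibition), compound 1 gives > 10000 nM, which is a limit of the assay and not a number. In this assay compound 2 gives > 10000 nM, likewise a limit. In this assay compound 3 gives > 10000 nM, again a limit. Compound 3 arises from compound 1 by hydrogen in place of methyl on an aromatic carbon; the step that the two limits leave unreadable from compound 1 to compound 3 stays unreadable because the limit of > 10000 nM in this assay, at which 3 of the 3 values shown sit, holds both ends. The difference between the cores of compound 1 and compound 2 is not broken down here. Compound 4 `O=C(Nc1cc(F)cc2cccnc12)c1cnccn1`, still unmeasured, arises from compound 2 by hydrogen in place of methyl on an aromatic carbon, the same change. Compound 4 is expected to move by a step that the limit leaves unreadable from compound 2 to compound 4, an expectation resting on compound 2 and its value > 10000 nM alongside (the limit of > 10000 nM in this assay, at which 3 of the 3 values shown sit). Compound 4 is therefore estimated at 15000 nM, between 5000 nM and 50000 nM.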

Compound 4, half-maximal inhibitory concentration: > 10000 nM
Compound 4: a limit, no number; the forecaster's own chance of this, stated with the estimate: 85%; the middle value lies beyond the limit too.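

No step can be read from compound 2 to compound 4, since both give only a limit and not a number: the limit of > 10000 nM in this assay, at which 4 of the 4 values shown sit.

The compounds shown leave open which structural change, if any, would bring a readable number in this assay.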